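Nitro for Cyano on a Sulfone Core: Expected Potency

The compounds below may be only part of what the source reports. "The series", "measured", "known", "first", "only" and "open" are said of these compounds alone.

Three compounds have been measured in a functional assay on VCaP cells (Homo sapiens) for antiproliferative activity, read by fluorescence and propidium iodide staining, with a stated time of 96 h; a higher number here means a weaker inhibitor, a lower number a stronger inhibitor:

Compound 1, `CC(O)(CSc1cc(C(F)(F)F)cc(C(F)(F)F)c1)C(=O)Nc1ccc(C#N)cc1C(F)(F)F`: 6650 nM
Compound 2, `CC(O)(CSc1cc(C(F)(F)F)cc(C(F)(F)F)c1)C(=O)Nc1ccc([N+](=O)[O-])cc1C(F)(F)F`: 3520 nM
Compound 3, `CC(O)(CS(=O)(=O)c1cc(C(F)(F)F)cc(C(F)(F)F)c1)C(=O)Nc1ccc(C#N)cc1C(F)(F)F`: "nd(insoluble)" (no result reported)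

Compound 1 and compound 2 share one core and differ in a single place: nitro in place of cyano on an aromatic carbon. In this assay this change gives a 1.9-fold lower number from compound 1 to compound 2 (0.28 log units; within the scatter), a step that stays within the usual scatter of repeated measurements, so the two values cannot be told apart with confidence.

Compound 3 carries a different core; the difference between the two cores is not broken down here. In this assay compound 3 gives "nd(insoluble)" (no result reported), which is no number at all, so nothing is known about how strong an inhibitor this core makes.

Compound 4, `CC(O)(CS(=O)(=O)c1cc(C(F)(F)F)cc(C(F)(F)F)c1)C(=O)Nc1ccc([N+](=O)[O-])cc1C(F)(F)F`, arises from compound 3 by nitro in place of cyano on an aromatic carbon. This is the same change as from compound 1 to compound 2, made at the same place on the ring. Since that change moved the value of compound 1 to compound 2 by a 1.9-fold lower number from compound 1 to compound 2 (0.28 log units; within the scatter), the same small step is expected here; the difficulty is that there is no starting number for compound 3, so the expectation for compound 4 must lean on compounds 1 and 2 and remain wide. For compound 4 in this assay a value of about 4500 nM is estimated, expected to lie between 1200 nM and 17000 nM, with a real chance that, as for compound 3, no number is obtained.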

Compound 4, half-maximal inhibitory concentration: 7110 nM
The estimate for compound 4 lay 1.6-fold (0.20 log units) below the measured number, and the stated range covers the measured number.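

In this assay, for the compounds shown here, compound 4 gives 7110 nM but compound 3 gives no number to compare with it, so no step from compound 3 to compound 4 can be read. As far as these compounds go, it remains open whether changing cyano to nitro alters the value on the core of compound 3 as little as it does in a 1.9-fold lower number from compound 1 to compound 2 (0.28 log units; within the scatter) on the core of compound 1. Nothing shown here offers an explanation for the value of compound 4.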